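Methyl-to-ethyl extension on the hydrazone carbon

The source may report more compounds than this note shows. Statements on the series, on what has been measured and on what is new or still open speak of the compounds shown alone.

Compound 1 `C/C(=N\NC(=O)c1ccc(-c2ccccc2)cc1)c1ccccc1O` is the reference point. In a toxicity assay (H9c2 cells) for cytotoxicity, with Rattus norvegicus as the target, read by neutral red uptake, with a stated time of 72 h (a lower number here means a stronger inhibitor, a higher number a weaker inhibitor), compound 1 gives > 100000 nM, which is a limit of the assay rather than a number. Compound 2 `C/C(=N\NC(=O)c1ccnnc1)c1ccccc1O` has a different acyl part; in this assay compound 2 gives 22800 nM. For compound 1 the only information is the limit, so its position among the numbers shown is open-ended (the limit of > 100000 nM in this assay, at which 1 of the 2 values shown sits).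

Compound 3 `CC/C(=N\NC(=O)c1ccc(-c2ccccc2)cc1)c1ccccc1O` carries methyl in place of hydrogen on a saturated chain carbon bound to a carbon with a double bond to nitrogen, that is, methyl in place of hydrogen on a saturated chain carbon bound to a carbon with a double bond to nitrogen. Among the compounds with values here, no measured pair shows such a change here. The step from compound 1 to compound 3 is expected to stay within the usual scatter, most likely at or near the limit again; the expected step is a step that the limit leaves unreadable from compound 1 to compound 3. For compound 3 the expected result in this assay is 120000 nM, with a range from 40000 nM to 300000 nM.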

Compound 3, half-maximal inhibitory concentration: > 100000 nM
Compound 3 ended at the assay's limit; the forecaster's own chance of this, stated with the estimate: 70%; the middle value does not contradict the limit.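

Compound 1 and compound 3 both rest at a limit of this assay rather than at a number, and no step can be read between them. The compounds shown leave open whether methyl to ethyl on this chain changes the read-out at all.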